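The compounds below may be only part of what the source reports. "The series", "measured", "known", "first", "only" and "open" are said of these compounds alone.

For the measured compounds named here, compound 3 `COc1ccc(C(=O)NO)cc1OCc1ccc(-c2cccnc2)cc1` gives 4970 nM in an assay on isolated protein for inhibition of sphingomyelin phosphodiesterase (Homo sapiens), read by fluorescence, with a stated time of 30 min (on this read-out lower numbers stand for stronger inhibition and higher numbers for weaker inhibition), the highest of the three numbers measured so far. Compound 2 `COc1ccc(C(=O)NO)cc1OCc1ccc(-c2ccccc2)cc1` gives 3630 nM in this assay. Compound 1 `COc1ccc(C(=O)NO)cc1OCc1ccc(-c2ccc(Cl)cc2)cc1` gives 340 nM in this assay. Among the measured steps, a 1.4-fold higher number from compound 2 to compound 3 (0.14 log units; within the scatter), so exchanging one six-membered aromatic group for another at the end of the molecule left the number essentially where it was. By contrast, an 11-fold higher number from compound 1 to compound 2 (1.03 log units; beyond the scatter) and a 15-fold higher number from compound 1 to compound 3 (1.16 log units; beyond the scatter), the only large movements in the set. Compound 4 `CCc1nc(-c2ccc(COc3cc(C(=O)NO)ccc3OC)cc2)no1` differs from compound 3 in one place: 5-ethyl-1,2,4-oxadiazol-3-yl in place of pyridin-3-yl on an aromatic carbon. Going by the values given here, none of the measured steps exchanges the terminal aromatic group for a five-membered ring, so the closest guide is the small step from compound 2 to compound 3, with the large steps from compound 1 showing how far this position can move the number. In this assay compound 4 is therefore expected to give about 3000 nM, within 800 nM to 12000 nM, which means an expected step of a 1.7-fold lower number from compound 3 to compound 4 (0.22 log units; within the scatter).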

Compound 4, half-maximal inhibitory concentration: 8220 nM
Compound 4: the middle estimate sits 2.7-fold (0.44 log units) below what was measured; the measured number falls inside the stated range.
By their numbers in this assay, from the lowest: compound 1; then compounds 2, 3 and 4 (each within the scatter of the next, the first and the last beyond it).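

In this assay the five-membered 5-ethyl-1,2,4-oxadiazol-3-yl ring stands close to the six-membered pyridin-3-yl group it replaces, with a 1.7-fold higher number from compound 3 to compound 4 (0.22 log units; within the scatter) showing that a change of ring size and hetero atoms at this position need not move the number beyond the scatter. Against phenyl the same ring gives a modest step, with a 2.3-fold higher number from compound 2 to compound 4 (0.35 log units; beyond the scatter) as the first movement beyond the scatter among the groups lacking chloro, while a 24-fold higher number from compound 1 to compound 4 (1.38 log units; beyond the scatter) is the largest step in the set and leaves 4-chlorophenyl as the only group here with a low number. Nothing available here explains these numbers.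

The compounds shown leave open whether a fluoro, methyl or methoxy group in place of the chloro on the terminal phenyl would also give a low number. They also leave open how a propyl or a cyclopropyl group in place of the ethyl on the oxadiazole ring would read.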